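This account rests on a few compounds, and the source may have more. Where it says the series, first, only, none or still open, it means among the compounds named here.

In a physicochemical assay for solubility (a higher number here means a more soluble compound, a lower number a less soluble compound), compound 1 `O=C(Nc1ccccc1Cl)c1cc(Cl)ccc1O` gives 5 ug/mL. Compound 3 `CC(=O)Nc1ccc(NC(=O)c2cc(Cl)ccc2O)c(Cl)c1` gives 5.1 ug/mL, and a 1.0-fold higher number from compound 1 to compound 3 (0.01 log units; within the scatter) leaves compound 3 level with compound 1 within the scatter. Compound 2 `O=C(Nc1ccc(C(F)(F)F)cc1Cl)c1cc(Cl)ccc1O` gives < 1 ug/mL, which is a limit of the assay and not a number.

Compound 4 `O=C(Nc1ccc(Cl)cc1Cl)c1cc(Cl)ccc1O` is reached from compound 3 by a single change, chloro in place of acetamido on an aromatic carbon, para to a large group: chloro in place of acetamido on an aromatic carbon.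

Chloro has no measured step of its own in this series, so the nearest guides are the steps that involve compound 2. These are an at least 5.0-fold lower number from compound 1 to compound 2 (0.69 log units; beyond the scatter) and an at least 5.1-fold higher number from compound 2 to compound 3 (0.70 log units; beyond the scatter), both beyond the scatter and both resting on a limit. Read in reverse, the step to compound 3 from compound 2 points to a modest move towards a lower number in this assay, not to a flat result. The expected size is a 3.4-fold lower number from compound 3 to compound 4 (0.53 log units; beyond the scatter). The estimate for compound 4 is 1.5 ug/mL, with an expected range of 0.6 ug/mL to 4 ug/mL, and a reading that returns only the limit of the assay remains possible.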

Compound 4, solubility: < 1 ug/mL
Compound 4 gave a limit, no number; the forecaster's own chance of this, stated with the estimate: 35%; at least 1.5-fold (0.17 log units) between middle value and limit.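

In this assay, the position para to a large group turns out to be sensitive to chloro as well as to trifluoromethyl: chloro in place of acetamido gives an at least 5.1-fold lower number from compound 3 to compound 4 (0.70 log units; beyond the scatter), and chloro in place of hydrogen gives an at least 5.0-fold lower number from compound 1 to compound 4 (0.69 log units; beyond the scatter). The lower reading at this position is therefore no longer tied to trifluoromethyl alone, and a single chlorine atom is enough to give it, while acetamido and hydrogen remain level within the scatter. Compound 2 and compound 4 both stand at a limit, so the step between them cannot be read and chloro and trifluoromethyl cannot be ordered here: the limit of < 1 ug/mL in this assay, at which 2 of the 4 values shown sit.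

The steps to compound 4 are known only as bounds, not as sizes. Going by these compounds, how an amine, a carboxylic acid or a longer chain would read at this position remains open.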